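Variation at the carbonyl carbon: compound 3

The source may hold more compounds than are shown below. What is called first, only, known or untested is meant among the compounds shown, and "the series" means these compounds.

Measured so far:
compound 1 `CCOC(=O)C1CCN(C(=O)CN2CN(c3ccccc3)C3(CCN(C(=O)c4ccc(C5CCCCC5)cc4)CC3)C2=O)CC1` — 900 nM
compound 2 `CC1(C)CC(OC(=O)CN2CN(c3ccccc3)C3(CCN(C(=O)c4ccc(C5CCCCC5)cc4)CC3)C2=O)CC(C)(C)N1` — 600 nM

In an assay on HEK293 cells for displacement of a labelled ligand from NPC1-like intracellular cholesterol transporter 1 (Homo sapiens) (a higher number here means a weaker inhibitor, a lower number a stronger inhibitor), compound 1 gives 900 nM and compound 2 gives 600 nM. Compound 2 has the lowest of the two numbers, but the step of a 1.5-fold lower number from compound 1 to compound 2 (0.18 log units; within the scatter) lies within the scatter, so the two compounds cannot be ordered.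

Compound 3 `O=C(CN1CN(c2ccccc2)C2(CCN(C(=O)c3ccc(C4CCCCC4)cc3)CC2)C1=O)NCCO` is not yet measured. It differs from compound 2 in one place: (2-hydroxyethyl)amino in place of (2,2,6,6-tetramethylpiperidin-4-yl)oxy on a carbonyl carbon. Among the measured compounds shown here, the only measured step that bears on this position is a 1.5-fold lower number from compound 1 to compound 2 (0.18 log units; within the scatter), in which a different exchange at the same carbonyl carbon moved the number within the scatter. No change beyond the scatter is therefore expected here; the expected step is a 1.2-fold higher number from compound 2 to compound 3 (0.07 log units; within the scatter), in either direction or none. For compound 3 the expected value is 700 nM, with a range from 300 nM to 1800 nM.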

Compound 3, half-maximal inhibitory concentration: 2000 nM
Compound 3: the middle estimate sits 2.9-fold (0.46 log units) below what was measured; measured number above the stated range.
By their numbers in this assay, from the lowest: compounds 2 and 1 (each within the scatter of the next); then compound 3.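

Read in this assay this carbonyl carbon does not take every group alike: (2-hydroxyethyl)amino gives a 3.3-fold higher number from compound 2 to compound 3 (0.52 log units; beyond the scatter) and also a 2.2-fold higher number from compound 1 to compound 3 (0.35 log units; beyond the scatter) so the step holds against both earlier compounds. The earlier exchange between 4-(ethoxycarbonyl)piperidin-1-yl and (2,2,6,6-tetramethylpiperidin-4-yl)oxy showed no such separation, so the position is now seen to respond to at least one exchange, though only modestly. Nothing at hand accounts for this step.

Several features change together in compound 3, so the hydroxyl, the open chain in place of a ring and the amino link in place of the oxy link cannot be told apart. An ethylamino group without the hydroxyl, or a (2,2,6,6-tetramethylpiperidin-4-yl)amino group, would separate these features at the same carbonyl carbon.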